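This account rests on a few compounds, and the source may have more. Where it says the series, first, only, none or still open, it means among the compounds named here.

Measured compounds, binding affinity by an assay on isolated protein for binding affinity to vascular endothelial growth factor A, long form (Homo sapiens), read by surface plasmon resonance; on this read-out higher numbers stand for weaker binding and lower numbers for tighter binding:

compound 1 `CCN(CC(=O)NC[C@H]1O[C@H](OC)[C@@H](OS(=O)(=O)O)[C@@H](OS(=O)(=O)O)[C@@H]1OS(=O)(=O)O)C(=O)CCCCCCCCCOS(=O)(=O)O` gives 545000 nM
compound 2 `CO[C@H]1O[C@H](CNC(=O)CN(C(C)=O)C2CCCCCC2)[C@@H](OS(=O)(=O)O)[C@H](OS(=O)(=O)O)[C@@H]1OS(=O)(=O)O` gives 3000000 nM
compound 3 `CO[C@H]1O[C@H](CNC(=O)CN(C(C)=O)c2ccccc2)[C@@H](OS(=O)(=O)O)[C@H](OS(=O)(=O)O)[C@@H]1OS(=O)(=O)O` gives 76000 nM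

Compound 1 stands second highest of the three numbers in this assay: compound 2 sits a step higher and compound 3 a step lower, both gaps beyond the scatter.

The unmeasured compound 4 `CCN(CC(=O)NC[C@H]1O[C@H](OC)[C@@H](OS(=O)(=O)O)[C@@H](OS(=O)(=O)O)[C@@H]1OS(=O)(=O)O)C(=O)CCc1ccccc1` keeps the core of compound 1 and changes only the acyl tail: phenyl in place of 7-(sulfooxy)heptyl on a saturated chain carbon, two bonds along the chain from a carbonyl carbon. Among the compounds with values here, only one measured step bears on this, and only loosely: a 39-fold lower number from compound 2 to compound 3 (1.60 log units; beyond the scatter), where the ring that enters is again a phenyl, though that change sits on an amide-type nitrogen rather than on the saturated chain carbon two bonds along the chain from a carbonyl carbon. Within the data shown here, no measured pair reports what losing a 7-(sulfooxy)heptyl does on its own; compound 1 carries this group and compound 3 does not, and compound 3 gives the lower number, which is all that can be read from those two.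

Taken together, a lower number is expected for compound 4, of moderate size rather than the full size seen from compound 2 to compound 3, since the site of change differs. The expected step is a 3.6-fold lower number from compound 1 to compound 4 (0.56 log units; beyond the scatter). Compound 4 is estimated at 150000 nM, within 40000 nM to 600000 nM.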

Compound 4, dissociation constant: 596000 nM
For compound 4 the middle estimate is 4.0-fold (0.60 log units) below the measured one; the measured number falls inside the stated range.
By their numbers in this assay, from the lowest: compound 3; then compounds 1 and 4 (each within the scatter of the next); then compound 2.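

In this assay, swapping the 7-(sulfooxy)heptyl of the acyl tail for phenyl gives a 1.1-fold higher number from compound 1 to compound 4 (0.04 log units; within the scatter), so the two groups cannot be told apart on this read-out at this place. In this pair, the tail can therefore lose its sulfooxy group and still read the same, and phenyl at this place does not repeat the large step it gives on an amide-type nitrogen, a 39-fold lower number from compound 2 to compound 3 (1.60 log units; beyond the scatter). No measurement on hand explains why these two different tails read alike, and the finding rests on this single pair.

A plain heptyl group at the same place would show whether the chain alone matches these two tails, while a carboxylic acid in place of the sulfooxy group would test another acid on that chain. Also open, as far as these compounds go, is whether a benzyl group or a cyclohexyl group at this place would read like phenyl, or whether any group here can move the number beyond the scatter.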